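Permeability notes: phenethyl for methoxyphenoxy on the core

The source may report more compounds than this note shows. Statements on the series, on what has been measured and on what is new or still open speak of the compounds shown alone.

Compound 2 `COc1ccc(Oc2ccc3c(NCCCNCc4cccc(OC)c4O)ccnc3c2)cc1` sits level with compound 1 `COc1ccc(Oc2ccc3c(NCCCNCc4cc(F)ccc4OC)ccnc3c2)cc1` and compound 3 `COc1ccc(Oc2ccc3c(NCCCNCc4ccco4)ccnc3c2)cc1` in an ADME assay for permeability, using PAMPA, with a stated time of 30 min, at pH 7.4; a higher number here means that the compound crosses the layer faster, a lower number that the compound crosses the layer more slowly: compound 2 gives 317 10^-6 cm/s, compound 1 gives 317 10^-6 cm/s and compound 3 gives 317 10^-6 cm/s. The steps among them, no change at the digits printed from compound 1 to compound 2 (within the scatter), no change at the digits printed from compound 1 to compound 3 (within the scatter) and no change at the digits printed from compound 2 to compound 3 (within the scatter), all stay within the scatter, and each of them changes only the aryl group on a saturated chain carbon bound to an amine nitrogen.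

Compound 4 `COc1cccc(CNCCCNc2ccnc3cc(CCc4ccccc4)ccc23)c1O` differs from compound 2 at another position: phenethyl in place of 4-methoxyphenoxy on an aromatic carbon. For the measured compounds named here, no measured step touches this position of the core, so the steps above bear on it only indirectly, by showing that exchanging an aryl group left this assay unmoved at the digits given. Going by the values given here, with no step of any size recorded, the working assumption is no change beyond the scatter in this assay.

Compound 4 is therefore expected at 317 10^-6 cm/s, in the range 160 10^-6 cm/s to 500 10^-6 cm/s. The expected step is no change at the digits printed from compound 2 to compound 4 (within the scatter).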

Compound 4, apparent permeability: 23 10^-6 cm/s
Compound 4: the middle estimate sits 14-fold (1.14 log units) above what was measured; the measured number lies below the stated range.
By their numbers in this assay, from the lowest: compound 4; then compounds 1, 2 and 3 (each within the scatter of the next).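

For the compounds shown here, the read-out in this assay responds at this position of the core, although exchanges of the aryl group on the chain left it level: phenethyl in place of 4-methoxyphenoxy on an aromatic carbon gives a 14-fold lower number from compound 2 to compound 4 (1.14 log units; beyond the scatter) and is the only step beyond the scatter. The change keeps one six-membered aromatic ring of carbon only and no net charge on both sides, while hydrogen-bond acceptors go from 2 in 4-methoxyphenoxy to 0 in phenethyl. Nothing measured on these compounds accounts for the step.

Open, as far as these compounds go, is whether the step tracks the oxygen linking the ring to the core, the methoxy on that ring, or the two-carbon link of phenethyl; a plain phenoxy or a benzyloxy at this place would begin to separate these. Also open, from the compounds shown here alone, is whether the same exchange gives a similar step with the chain groups of compound 1 and compound 3.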